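The source may report more compounds than this note shows. Statements on the series, on what has been measured and on what is new or still open speak of the compounds shown alone.

Compound 1 `CCOC(=O)/C=C/c1ccncc1-c1ccc2c(cnn2C)c1` — > 10000 nM
Compound 2 `CCOC(=O)/C=C/c1ccncc1-c1ccc2ccccc2c1` — > 10000 nM
Compound 3 `O=C(O)/C=C/c1ccncc1-c1ccc2ccccc2c1` — > 10000 nM

The three measured compounds were tested in a functional assay on KB cells (Homo sapiens) for inhibition, read by sulforhodamine B assay, with a stated time of 72 h; on this read-out lower numbers stand for stronger inhibition of growth and higher numbers for weaker inhibition of growth. None of them gave a number: the value for compound 1 is a limit of the assay, and so are the values for compound 2 and for compound 3. The difference between the core of compound 1 and the core of compound 2 is not broken down here. Compound 2 and compound 3 differ in one place, (hydrogen in place of ethyl on an oxygen next to a carbonyl group), and the step that the two limits leave unreadable from compound 2 to compound 3 cannot be read, since both values are limits. What the measurements do show is the limit of > 10000 nM in this assay, at which 3 of the 3 values shown sit, at which every value shown sits.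

The unmeasured compound 4 `Cn1ncc2cc(-c3cnccc3/C=C/C(=O)O)ccc21` arises from compound 1 by the same change, (hydrogen in place of ethyl on an oxygen next to a carbonyl group), on the core of compound 1. The place of the change reads the same in both pairs. With compound 1 already at the limit and the earlier step unreadable, nothing in these data points toward a change in either direction. Compound 4 is therefore expected to stay at the limit in this assay, with an estimated step that the limit leaves unreadable from compound 1 to compound 4. The estimate for compound 4 is 20000 nM, between 10000 nM and 50000 nM.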

Compound 4, concentration for 50% growth inhibition: > 10000 nM
Compound 4 was reported as a limit; the forecaster's own chance of this, stated with the estimate: 85%; the middle value is on the limit's open side.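

Compound 1 and compound 4 are both reported only as a limit of the assay, not as a number, so no step can be read between them. The compounds shown leave open whether hydrogen in place of ethyl changes growth inhibition in this assay on either core, and how strongly any of them acts, for the only finding is this: the limit of > 10000 nM in this assay, at which 4 of the 4 values shown sit.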